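Methyl on an Aromatic Nitrogen and Lipophilicity

This account rests on a few compounds, and the source may have more. Where it says the series, first, only, none or still open, it means among the compounds named here.

Compound 1 `CN(C)C(=O)c1c[nH]c2ccccc12`: 0.4
Compound 2 `O=C(Cn1ccccc1=O)Nc1cc2ccccc2[nH]1`: 0.4
Compound 3 `Cn1c(NC(=O)Cn2ccccc2=O)cc2ccccc21`: 1.1

These three compounds were measured in a physicochemical assay for lipophilicity; a lower number here means a more polar compound, a higher number a more lipophilic compound. Compound 1 and compound 2 sit level at the digits shown, within the scatter; how their two cores differ is not broken down here. Compound 3 differs from compound 2 in one place: methyl in place of hydrogen on an aromatic nitrogen. That change gave a number 0.70 log units higher from compound 2 to compound 3 (beyond the scatter).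

Compound 4 `CN(C)C(=O)c1cn(C)c2ccccc12` has not yet been measured in this assay. It differs from compound 1 in one place: methyl in place of hydrogen on an aromatic nitrogen. The surroundings are not identical: in compound 2 the methyl enters next to the ring atom that bears a large group, in compound 1 two ring bonds from the ring atom that bears a dimethylcarbamoyl group, so this is the same kind of change, not the same one.

From compound 1 to compound 4 the step is estimated at a number 0.60 log units higher from compound 1 to compound 4 (beyond the scatter), because the same kind of change gave a number 0.70 log units higher from compound 2 to compound 3 (beyond the scatter). Compound 4 is therefore expected to give 1, with a likely range from 0.6 to 1.4.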

Compound 4, partition coefficient: 1.3
Compound 4: the middle estimate sits 0.30 log units below what was measured; measured number inside the range.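

In this assay, methyl in place of hydrogen on an aromatic nitrogen gave a number 0.90 log units higher from compound 1 to compound 4 (beyond the scatter) on one core and a number 0.70 log units higher from compound 2 to compound 3 (beyond the scatter) on the other. Across these two pairs, then, the change moved the number in the same direction on both cores, so the direction carried over. Two pairs set no rule for other cores, and nothing available here explains the size of either step.

The only group shown entering on the aromatic nitrogen is methyl, so it remains open how an ethyl group or a longer chain would behave there. As far as these compounds go, it is also open whether the step would hold on a core carrying an amine or a carboxylic acid.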